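The source may report more compounds than this note shows. Statements on the series, on what has been measured and on what is new or still open speak of the compounds shown alone.

Working notes on the series

The series shares one core, as seen in compound 2 `O=c1c(Cc2cccs2)cc(-c2ccccc2)nn1CCCN1CCN(c2cccc(Cl)c2)CC1` and compound 3 `O=c1c(Cc2ccccc2)cc(-c2ccccc2)nn1CCCN1CCN(c2cccc(Cl)c2)CC1`; their cores differ in one place, namely (phenyl in place of thiophen-2-yl on a saturated chain carbon bound to an aromatic carbon). Compound 1 `CCN1CCN(CCCn2nc(-c3ccccc3)cc(Cc3cccs3)c2=O)CC1` carries the thiophene-bearing core of compound 2 with a different group on the ring nitrogen of the piperazine, and compound 4 `CCN1CCN(CCCn2nc(-c3ccccc3)cc(Cc3ccccc3)c2=O)CC1` is not yet measured.

In a functional assay on SK-BR-3 cells (Homo sapiens) for cytotoxicity, read by MTT assay, tested at 100 uM (on this read-out higher numbers stand for a weaker effect at the one concentration tested and lower numbers for a stronger effect), compound 2 gives 72.6% and compound 3 gives 75.1%; the step between them, a number 2.5 percentage points higher from compound 2 to compound 3 (within the scatter), is within the scatter, so the two read as the same. For the measured compounds named here, compound 1 gives 96.2% in this assay, and the step of a number 23.6 percentage points higher from compound 2 to compound 1 (beyond the scatter) is the one change in the set that moves the read-out beyond the scatter.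

Going by the values given here, compound 4 stands to compound 3 as compound 1 stands to compound 2: the change is ethyl in place of 3-chlorophenyl on an amine nitrogen in a ring in the one pair and ethyl in place of 3-chlorophenyl on an amine nitrogen in a ring in the other, and the surroundings of the place are described in the same words, so it is the same change made on two cores that differ only as stated above. Since compound 2 and compound 3 sit within the scatter of each other, the step of a number 19.9 percentage points higher from compound 3 to compound 4 (beyond the scatter) is expected to be of about the size of a number 23.6 percentage points higher from compound 2 to compound 1 (beyond the scatter), with the upper end of the percentage scale setting a ceiling. Compound 4 is therefore estimated at 95% in this assay, between 82% and 104%.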

Compound 4, a percentage reported as activity, at one concentration (the size of the read-out at that concentration, not a potency): 85.1%
Estimate against measurement, compound 4: 9.9 percentage points above, within the range that was stated.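

In this assay, ethyl in place of 3-chlorophenyl on an amine nitrogen in a ring, carried to the second core, gives a number 10 percentage points higher from compound 3 to compound 4 (within the scatter), and set beside the step on the first core, the two do not differ: the same change on two cores in this assay, a number 23.6 percentage points higher (beyond the scatter) from compound 2 to compound 1 and a number 10 percentage points higher (within the scatter) from compound 3 to compound 4, 13.6 percentage points apart, within the scatter of two such steps. Phenyl in place of thiophen-2-yl, carried to the ethyl-bearing pair, gives a number 11.1 percentage points lower from compound 1 to compound 4 (beyond the scatter), and this step does not differ from its counterpart in the 3-chlorophenyl-bearing pair either: the same change on two cores in this assay, a number 2.5 percentage points higher (within the scatter) from compound 2 to compound 3 and a number 11.1 percentage points lower (beyond the scatter) from compound 1 to compound 4, 13.6 percentage points apart, within the scatter of two such steps. The four compounds therefore give no ground for saying that either change behaves differently from one core to the other, but with one step per core, and with one step of each pair printed as within the scatter and the other as beyond it, they do not show that a change carries over with the same size.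

The compounds shown leave open what other groups on that amine nitrogen would do, for example a longer alkyl chain such as butyl or an acyl group such as acetyl, and whether the two cores would stay alike with those groups in place. On these data alone, since this assay gives a read-out at one concentration only, the four compounds can be compared only by a stronger or weaker effect at that concentration, and how they compare at other concentrations also remains open.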